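Benzyl to benzoyl on an indoline urea: expected activity

The compounds below may be only part of what the source reports. "The series", "measured", "known", "first", "only" and "open" are said of these compounds alone.

Measured so far:
- compound 1, `Cc1ccc(CN2CCc3cc(NC(=O)NCc4ccncc4)ccc32)cc1`, "not determined" (no result reported)
- compound 2, `CC(C)c1nc2ccc(NC(=O)NCc3ccncc3)cn2n1`, 0%
- compound 3, `O=C(NCc1cn[nH]c1)Nc1ccc2nc(-c3ccccc3)nn2c1`, 118%

Compound 1 carries a urea linking a pyridinylmethyl group to a fused two-ring core. In an assay on HEK293-A cells for activation of Nicotinamide phosphoribosyltransferase (Homo sapiens), tested at 1 uM (on this read-out lower numbers stand for a weaker effect and higher numbers for a stronger effect at the one concentration tested), compound 1 has no number, so there is no starting value on which to set a step. Compound 2 and compound 3 share the urea but sit on other cores; in this assay compound 2 gives 0% and compound 3 gives 118%, which shows how wide the range of this read-out can be across the series.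

Compound 4, `Cc1ccc(C(=O)N2CCc3cc(NC(=O)NCc4ccncc4)ccc32)cc1`, differs from compound 1 in one place: (4-methylphenyl)carbonyl in place of 4-methylbenzyl on a nitrogen on an aromatic ring in a ring. Going by the values given here, no measured pair with this change exists, so its size in this assay cannot be drawn from the data; the change is expected to be anywhere from none beyond the scatter to a large one in either direction.

Compound 4 is estimated to give about 40% in this assay, with a range from 0% to 110%.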

Compound 4, a percentage reported as activity, at one concentration (the size of the read-out at that concentration, not a potency): 25%
Compound 4: middle estimate off by 15 percentage points, on the high side, within the range that was stated.
By their numbers in this assay, from the lowest: compound 2; then compound 4; then compound 3.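

In this assay no step from compound 1 to compound 4 can be read, and nothing shown here explains the result for compound 4. The compounds shown leave open how replacing 4-methylbenzyl with (4-methylphenyl)carbonyl on the shared core changes the read-out.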